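The source may report more compounds than this note shows. Statements on the series, on what has been measured and on what is new or still open speak of the compounds shown alone.

Measured in an ADME assay on H1-HeLa cells (Homo sapiens) for cytotoxicity, read by MTT assay, with a stated time of 3 days; a lower number here means that less compound is tolerated, a higher number that more compound is tolerated:
- compound 1 `CNC(=O)c1cc(Oc2ccc3ccc(C(=O)OC)cc3c2)ccn1`: 53500 nM
- compound 2 `CCOC(=O)c1ccc2ccc(Oc3ccnc(C(=O)NC)c3)cc2c1`: 20800 nM
- compound 3 `CNC(=O)c1cc(Oc2ccc3ccc(C(=O)OC(C)C)cc3c2)ccn1`: 13800 nM

All three share one core and differ only in the group on the oxygen next to a carbonyl group. Compound 3 stands close to one neighbour and apart from the other, with a 1.5-fold lower number from compound 2 to compound 3 (0.18 log units; within the scatter) and a 3.9-fold lower number from compound 1 to compound 3 (0.59 log units; beyond the scatter).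

Compound 4 `CCC(C)OC(=O)c1ccc2ccc(Oc3ccnc(C(=O)NC)c3)cc2c1` keeps everything else and turns isopropyl to sec-butyl, with methyl in place of hydrogen on a saturated chain carbon, two bonds along the chain from an oxygen next to a carbonyl group.

Two measured steps also enlarge this group, and they bear most directly on the change. One is a 2.6-fold lower number from compound 1 to compound 2 (0.41 log units; beyond the scatter), which lies beyond the scatter. The other is a 1.5-fold lower number from compound 2 to compound 3 (0.18 log units; within the scatter), which lies within it. On that evidence, a small move towards a lower number is expected, probably not beyond the scatter. The expected step is a 1.4-fold lower number from compound 3 to compound 4 (0.14 log units; within the scatter). For compound 4 the estimated value is 10000 nM, with an expected range of 4500 nM to 21000 nM.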

Compound 4, half-maximal cytotoxic concentration: 16000 nM
Compound 4: middle estimate off by 1.6-fold (0.20 log units), on the low side; the measured number falls inside the stated range.
By their numbers in this assay, from the lowest: compounds 3, 4 and 2 (each within the scatter of the next); then compound 1.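

Adding a methyl group on a saturated chain carbon, two bonds along the chain from an oxygen next to a carbonyl group, makes no clear difference in this assay, with a 1.2-fold higher number from compound 3 to compound 4 (0.06 log units; within the scatter). Compound 4 also cannot be told apart from the ethyl group of compound 2, with a 1.3-fold lower number from compound 2 to compound 4 (0.11 log units; within the scatter), whereas the methyl group of compound 1 still stands apart, with a 3.3-fold lower number from compound 1 to compound 4 (0.52 log units; beyond the scatter). Enlarging this group therefore registers at the first added carbon but not at this further carbon, so the same added methyl does not count equally in both places: the same change on two cores in this assay, a 2.6-fold lower number (0.41 log units; beyond the scatter) from compound 1 to compound 2 and a 1.2-fold higher number (0.06 log units; within the scatter) from compound 3 to compound 4, 3.0-fold (0.47 log units) apart, beyond the scatter of two such steps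

The compounds shown leave open whether a longer chain, such as n-hexyl, would lower the number further. They also leave open how an amine or a carboxylic acid at the end of this chain would behave.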